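This account rests on a few compounds, and the source may have more. Where it says the series, first, only, none or still open, it means among the compounds named here.

Within the data shown here, in a functional assay on SK-MEL-2 cells (Homo sapiens) for cytotoxicity (on this read-out lower numbers stand for stronger inhibition and higher numbers for weaker inhibition), compound 2 `Cc1ccc(S(=O)(=O)N2CC(c3ccccc3)NC2=O)cc1` gives 2530 nM, the lower of the two numbers measured so far and well beyond the scatter from compound 1 `Cc1ccc(C2CN(S(=O)(=O)c3ccc(Cl)cc3)C(=O)N2)cc1`, which gives 123000 nM. Compound 3 `O=C1NC(c2ccccc2)CN1S(=O)(=O)c1ccc(Cl)cc1` has not yet been measured. It differs from compound 2 at one place: chloro in place of methyl on an aromatic carbon, para to a large group. Among the measured compounds shown here, no measured pair isolates this change, so the data give no direct guide to its size. The wide gap between the two measured compounds cannot be assigned to any single structural feature, but it leaves room for a weaker result. A moderate move toward a higher number is therefore expected in this assay, an estimated step of a 2.4-fold higher number from compound 2 to compound 3 (0.38 log units; beyond the scatter). For compound 3, the estimated value is 6000 nM, with an expected range of 1500 nM to 40000 nM.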

Compound 3, half-maximal inhibitory concentration: 1430 nM
For compound 3 the middle estimate is 4.2-fold (0.62 log units) above the measured one; the whole stated range lies above it.
By their numbers in this assay, from the lowest: compounds 3 and 2 (each within the scatter of the next); then compound 1.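

In this assay, the change from 4-methylphenyl to 4-chlorophenyl, para to a large group, gives a 1.8-fold lower number from compound 2 to compound 3 (0.25 log units; within the scatter), so at this position chloro and methyl cannot be told apart on this read-out. The other pair shows that a single change elsewhere can carry a large step: dropping a methyl group from the aromatic ring gives an 86-fold lower number from compound 1 to compound 3 (1.93 log units; beyond the scatter), with chloro present in both compounds. Nothing available bears on the reason for either result.

From the compounds shown here alone, whether an amine, a methoxy group or a carboxylic acid in place of chloro or methyl would also stay within the scatter remains open. Going by these compounds, it is equally open whether hydrogen in place of that methyl would give a step of similar size in a compound carrying 4-methylphenyl rather than 4-chlorophenyl.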